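The compounds below may be only part of what the source reports. "The series", "measured", "known", "first", "only" and "open" are said of these compounds alone.

Measured so far:
compound 1 `CN(C)C(=O)c1cc2cnc(Nc3ccc(S(=O)(=O)NCCCCCN=C=S)cc3)nc2n1C1CCCC1`: 83.4%
compound 2 `CN(C)C(=O)c1cc2cnc(Nc3ccc(C(=O)NCCCCCCN=C=S)cc3)nc2n1C1CCCC1`: 85%

In a functional assay on NCI-H1299 cells (Homo sapiens) for inhibition, read by CCK-8 assay, with a stated time of 72 h, tested at 10 uM (a higher number here means a stronger effect of the compound at the concentration tested, a lower number a weaker effect), compound 2 stands highest of the two numbers, though within the scatter of compound 1: a number 1.6 percentage points higher from compound 1 to compound 2 (within the scatter). Compound 3 `CN(C)C(=O)c1cc2cnc(Nc3ccc(NC(=O)CCCCCCN=C=S)cc3)nc2n1C1CCCC1` differs from compound 2 by a group of 12 heavy atoms (8 carbon, 2 nitrogen, 1 oxygen, 1 sulfur; no ring) in place of a group of 12 heavy atoms (8 carbon, 2 nitrogen, 1 oxygen, 1 sulfur; no ring), on an aromatic carbon. Among the measured compounds shown here, no measured step exchanges these two groups; the one step known, at the same aromatic carbon, stayed within the scatter. On that single comparison no step beyond the scatter is expected, a number 3 percentage points lower from compound 2 to compound 3 (within the scatter). For compound 3 the estimated value in this assay is 82%, with a range from 66% to 92%.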

Compound 3, a percentage reported as inhibition, at one concentration (the size of the read-out at that concentration, not a potency): 80.9%
Compound 3: middle estimate off by 1.1 percentage points, on the high side, within the range that was stated.
By their numbers in this assay, from the lowest: compounds 3, 1 and 2 (each within the scatter of the next).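

In this assay, joining the same atoms differently on this aromatic carbon, para to a large group, gives a number 4.1 percentage points lower from compound 2 to compound 3 (within the scatter), so this exchange is tolerated at the tested concentration. The exchange from the sulfur-containing group gives a number 2.5 percentage points lower from compound 1 to compound 3 (within the scatter), and all three groups at this position remain unseparated by this read-out. No measured evidence bears on this result. Open, as far as these compounds go, is whether an amine in place of the terminal isothiocyanate, or a longer chain, would keep the read-out. Also open, from the compounds shown here alone, is whether these three compounds would separate at lower concentrations.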